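The compounds below may be only part of what the source reports. "The series", "measured", "known", "first", "only" and "open" are said of these compounds alone.

Measured so far in a functional assay on MCF7 cells (Homo sapiens) for antiproliferative activity, read by MTT assay, with a stated time of 72 h; on this read-out higher numbers stand for weaker inhibition and lower numbers for stronger inhibition:
- compound 1 `Nc1nc(N)c2cc(CSC(=S)N3CCN(c4ccccc4F)CC3)ccc2n1`: 4840 nM
- compound 2 `Nc1nc(N)c2cc(CSC(=S)N3CCN(c4ccc(F)cc4F)CC3)ccc2n1`: 3670 nM

Compound 2, at 3670 nM, lies within the scatter of compound 1, so the two cannot be ordered. Compound 3 `CC(=O)c1ccc(N2CCN(C(=S)SCc3ccc4nc(N)nc(N)c4c3)CC2)cc1` is not yet measured. It differs from compound 2 by 4-acetylphenyl in place of 2,4-difluorophenyl on an amine nitrogen in a ring. Going by the values given here, the only measured step, a 1.3-fold lower number from compound 1 to compound 2 (0.12 log units; within the scatter), is a fluoro in place of hydrogen on an aromatic carbon, and no measured compound carries the acetyl group. The step expected in this assay is a 1.1-fold higher number from compound 2 to compound 3 (0.04 log units; within the scatter), with none expected beyond the scatter. Compound 3 is estimated at 4000 nM, with an expected range of 1500 nM to 11000 nM.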

Compound 3, half-maximal inhibitory concentration: 2490 nM
For compound 3 the middle estimate is 1.6-fold (0.21 log units) above the measured one, within the range that was stated.
By their numbers in this assay, from the lowest: compounds 3, 2 and 1 (each within the scatter of the next).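

In this assay the phenyl ring on the ring amine nitrogen takes 4-acetylphenyl, which brings a carbonyl and a hydrogen-bond acceptor, with a 1.5-fold lower number from compound 2 to compound 3 (0.17 log units; within the scatter) and a 1.9-fold lower number from compound 1 to compound 3 (0.29 log units; within the scatter). Both steps lie within the scatter, so 4-acetylphenyl cannot be ordered against 2,4-difluorophenyl or the 2-fluorophenyl group. Nothing measured here explains the closeness of these numbers. Open, going by these compounds, is whether any group at this position moves the number beyond the scatter. A carboxylic acid or an amine on that phenyl ring would test this.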